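The source may hold more compounds than are shown below. What is called first, only, known or untested is meant among the compounds shown, and "the series" means these compounds.

Compound 1 `Cc1cc(Cl)ccc1Nc1nc(C(F)(F)F)ccc1C(=O)N/N=C/c1ccc(F)cc1`, compound 2 `Cc1cc(Cl)ccc1Nc1nc(C(F)(F)F)ccc1C(=O)N/N=C/c1cccc(O)c1` and compound 3 `Cc1cc(Cl)ccc1Nc1nc(C(F)(F)F)ccc1C(=O)N/N=C/c1ccc(Cl)cc1` share one core and differ only in the aryl group on the carbon with a double bond to nitrogen. In a functional assay on NCI60 cells (Homo sapiens) for cytotoxicity, read by sulforhodamine B assay, with a stated time of 48 h (on this read-out lower numbers stand for stronger inhibition of growth and higher numbers for weaker inhibition of growth), compound 1 gives 7080 nM, compound 2 gives 11000 nM and compound 3 gives 7590 nM. The steps of a 1.6-fold higher number from compound 1 to compound 2 (0.19 log units; within the scatter), a 1.1-fold higher number from compound 1 to compound 3 (0.03 log units; within the scatter) and a 1.4-fold lower number from compound 2 to compound 3 (0.16 log units; within the scatter) all stay within the scatter, so compound 3 stands among three numbers that cannot be told apart. Compound 4 `Cc1ccc(Cl)cc1Nc1nc(C(F)(F)F)ccc1C(=O)N/N=C/c1ccc(Cl)cc1` keeps that aryl group of compound 3 and alters the other end: 5-chloro-2-methylphenyl in place of 4-chloro-2-methylphenyl on a nitrogen on an aromatic ring. Among the compounds with values here, no measured step touches the group on that nitrogen, so nothing here argues for a move beyond the scatter. Compound 4 is therefore expected at 9000 nM, within 3000 nM to 30000 nM. The expected step is a 1.2-fold higher number from compound 3 to compound 4 (0.07 log units; within the scatter).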

Compound 4, concentration for total growth inhibition: 5250 nM
Compound 4: middle estimate off by 1.7-fold (0.23 log units), on the high side, and the stated range covers the measured number.
By their numbers in this assay, from the lowest: compounds 4, 1, 3 and 2 (each within the scatter of the next, the first and the last beyond it).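

In this assay, within the data shown here, the first change at this end of the series, 5-chloro-2-methylphenyl in place of 4-chloro-2-methylphenyl on a nitrogen on an aromatic ring, gives a 1.4-fold lower number from compound 3 to compound 4 (0.16 log units; within the scatter) and so no readable difference between these two groups. The group on this nitrogen therefore joins the aryl group on the carbon with a double bond to nitrogen as a place with no step beyond the scatter so far. No evidence shown bears on this result. Still open, on these data alone, is whether a methoxy or an amine on that phenyl ring, in place of the chloro, would give a step beyond the scatter. Also open, as far as these compounds go, is whether the 5-chloro-2-methylphenyl group behaves alike with the 4-fluorophenyl or 3-hydroxyphenyl partner.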